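Methoxy to phenoxy in a series at its limit

The source may hold more compounds than are shown below. What is called first, only, known or untested is meant among the compounds shown, and "the series" means these compounds.

Measured in an ADME assay on HepG2 cells (Homo sapiens) for cytotoxicity, read by luminescence, with a stated time of 72 h (on this read-out lower numbers stand for an effect already at smaller amounts and higher numbers for an effect only at larger amounts of compound), each value a limit:
- Compound 1 `CCOC(=O)c1c(-c2cccc(Oc3ccccc3)c2)[nH]c2cc(Cl)c(OC)cc2c1=O` gives > 21500 nM as a limit
- Compound 2 `CCOC(=O)c1c(-c2cccc(-c3ccccc3)c2)[nH]c2cc(Cl)c(Cl)cc2c1=O` gives > 21500 nM as a limit
- Compound 3 `CCOC(=O)c1c(-c2cccc(OC)c2)[nH]c2cc(Cl)c(Cl)cc2c1=O` gives > 21500 nM as a limit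

Compound 3 thus stands without a number, and the series as a whole shows the limit of > 21500 nM in this assay, at which 3 of the 3 values shown sit, and no exact reading. Compound 4 `CCOC(=O)c1c(-c2cccc(Oc3ccccc3)c2)[nH]c2cc(Cl)c(Cl)cc2c1=O` differs from compound 3 by phenyl in place of methyl on an oxygen on an aromatic ring. Going by the values given here, the one measured step that bears on this change is a step that the two limits leave unreadable from compound 2 to compound 3 (methoxy in place of phenyl on an aromatic carbon), and it offers no size to carry over. Compound 1 also carries phenoxy and reports > 21500 nM as a limit too. No step beyond the scatter is therefore expected in this assay, and compound 4 is expected to report a limit again. The expected step is a step that the limit leaves unreadable from compound 3 to compound 4 on this reading. For compound 4 the estimated value is 25000 nM within a range from 15000 nM to 45000 nM as the expected span.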

Compound 4, half-maximal effective concentration: > 21500 nM
Compound 4: only a limit was reported; the forecaster's own chance of this, stated with the estimate: 85%; the middle value does not contradict the limit.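

Compound 4 also reports only a limit, so its steps from compound 1, compound 2 and compound 3 cannot be read. All the compounds end at the same limit: the limit of > 21500 nM in this assay, at which 4 of the 4 values shown sit.

Whether any of these changes moves the half-maximal effective concentration at all stays open: no compound shown has an exact reading.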